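Anilide swaps at the amide nitrogen: tolerated concentration notes

This account rests on a few compounds, and the source may have more. Where it says the series, first, only, none or still open, it means among the compounds named here.

Within the data shown here, the three measured members share one core and differ only in the aryl group on the amide nitrogen. Compound 1 `COc1ccc2c(=O)c(/C=C/C(=O)Nc3cccc(Cl)c3)coc2c1` carries a 3-chlorophenyl there; in an ADME assay on HepG2 2.2.15 cells (Homo sapiens) for cytotoxicity, read by MTT assay, with stated times of 48 h and 9 days (a lower number here means that less compound is tolerated, a higher number that more compound is tolerated), compound 1 gives 1100000 nM. Compound 2 `COc1ccc2c(=O)c(/C=C/C(=O)Nc3ccc(C)cc3)coc2c1` carries a 4-methylphenyl, and in this assay compound 2 gives 979000 nM. Compound 3 `COc1ccc2c(=O)c(/C=C/C(=O)Nc3cc(C)ccc3C)coc2c1` carries a 2,5-dimethylphenyl, and in this assay compound 3 gives 1100000 nM. The measured steps are all small: a 1.1-fold lower number from compound 1 to compound 2 (0.05 log units; within the scatter), no change at the digits printed from compound 1 to compound 3 (within the scatter) and a 1.1-fold higher number from compound 2 to compound 3 (0.05 log units; within the scatter). Compound 3 thus stands level with compound 1 at the digits shown, the two sharing the highest number of the three, with compound 2 nearest and within the scatter of both.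

Compound 4 `COc1ccc2c(=O)c(/C=C/C(=O)Nc3ccc(Cl)cc3)coc2c1` has not yet been measured in this assay. It differs from compound 3 in one place: 4-chlorophenyl in place of 2,5-dimethylphenyl on an amide-type nitrogen. Among the measured compounds shown here, two measured steps bear on this change, since each exchanges a chlorophenyl against a methyl-bearing phenyl on the same nitrogen: no change at the digits printed from compound 1 to compound 3 (within the scatter) and a 1.1-fold lower number from compound 1 to compound 2 (0.05 log units; within the scatter), both within the scatter. For the measured compounds named here, no step among the three numbers reaches beyond the scatter, so the step to compound 4 is expected to be a 1.0-fold lower number from compound 3 to compound 4 (0.02 log units; within the scatter). Compound 4 is expected to give 1050000 nM, within a range from 600000 nM to 1800000 nM.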

Compound 4, half-maximal cytotoxic concentration: 272000 nM
The estimate for compound 4 lay 3.9-fold (0.59 log units) above the measured number; measured number outside the range, below it.
By their numbers in this assay, from the lowest: compound 4; then compounds 2, 1 and 3 (each within the scatter of the next).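

Notes on the step: in this assay the aryl group on the amide-type nitrogen is no longer a silent position, since 4-chlorophenyl in place of 2,5-dimethylphenyl gives a 4.0-fold lower number from compound 3 to compound 4 (0.61 log units; beyond the scatter) and thus moves beyond the scatter where the earlier swaps did not. Where the chloro sits on the phenyl ring counts among these compounds: 4-chlorophenyl in place of 3-chlorophenyl gives a 4.0-fold lower number from compound 1 to compound 4 (0.61 log units; beyond the scatter) even though both groups are chlorophenyls. The para-free reading of the pair with compound 2 points the same way, as chloro in place of methyl on an aromatic carbon gives a 3.6-fold lower number from compound 2 to compound 4 (0.56 log units; beyond the scatter) and so neither the 3-chlorophenyl of compound 1 nor the 4-methylphenyl of compound 2 goes with a number this low; among the four compounds only the 4-chlorophenyl does.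

The compounds shown leave open whether a 4-bromophenyl or a 4-methoxyphenyl on the same nitrogen would sit with compound 4 or with compounds 1, 2 and 3. Nothing available here bears on the origin of this step.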